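This account rests on a few compounds, and the source may have more. Where it says the series, first, only, none or still open, it means among the compounds named here.

Measured in a functional assay on A549 cells (Homo sapiens) for antiproliferative activity, read by CCK-8 assay, with a stated time of 72 h; on this read-out lower numbers stand for stronger inhibition and higher numbers for weaker inhibition:
Compound 1 `O=C(Nc1cccc(-c2oc3cc(-c4ccc(F)cc4)ccc3c(=O)c2O)c1)c1ccc(F)cc1` gives 6930 nM.
Compound 2 `O=C(Nc1cccc(-c2oc3cc(-c4ccc(F)cc4)ccc3c(=O)c2O)c1)c1cc(F)cc(F)c1` gives 7620 nM.
Compound 3 `O=C(Nc1cccc(-c2oc3cc(-c4ccc(F)cc4)ccc3c(=O)c2O)c1)c1cnc(Cl)nc1Cl` gives > 100000 nM, which is a limit of the assay rather than a number.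

Compound 3 thus sits at the limit of > 100000 nM in this assay, at which 1 of the 3 values shown sits. Compound 1 and compound 2 both lie far under it. Compound 4 `N#Cc1ccc(C(=O)Nc2cccc(-c3oc4cc(-c5ccc(F)cc5)ccc4c(=O)c3O)c2)cc1` differs from compound 3 by 4-cyanophenyl in place of 2,4-dichloropyrimidin-5-yl on a carbonyl carbon. The measured steps that bear on this change run the other way: an at least 14-fold higher number from compound 1 to compound 3 (1.15 log units; beyond the scatter) and an at least 13-fold higher number from compound 2 to compound 3 (1.11 log units; beyond the scatter), both large, whereas a 1.1-fold higher number from compound 1 to compound 2 (0.04 log units; within the scatter). Because an at least 14-fold higher number from compound 1 to compound 3 (1.15 log units; beyond the scatter) accompanied the loss of a phenyl ring on that carbonyl, and compound 4 brings a phenyl ring back, a large step downward in this assay is expected for compound 4. Compound 4 is therefore estimated at 9000 nM, between 3000 nM and 40000 nM, an expected step of an at least 11-fold lower number from compound 3 to compound 4 (1.04 log units; beyond the scatter).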

Compound 4, half-maximal inhibitory concentration: 2360 nM
For compound 4 the middle estimate is 3.8-fold (0.58 log units) above the measured one; measured number outside the range, below it.
By their numbers in this assay, from the lowest: compound 4; then compounds 1 and 2 (each within the scatter of the next). At a limit, above all of these: compound 3.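

In this assay, this place on the carbonyl carbon allows a lower number than the fluorinated rings gave: cyano in place of fluoro gives a 2.9-fold lower number from compound 1 to compound 4 (0.47 log units; beyond the scatter), and 4-cyanophenyl in place of 3,5-difluorophenyl gives a 3.2-fold lower number from compound 2 to compound 4 (0.51 log units; beyond the scatter). Against the pyrimidine ring, 4-cyanophenyl in place of 2,4-dichloropyrimidin-5-yl gives an at least 42-fold lower number from compound 3 to compound 4 (1.62 log units; beyond the scatter). The value of compound 3 is a limit of the assay, not a number: the limit of > 100000 nM in this assay, at which 1 of the 4 values shown sits.

With only one nitrile compound shown, it stays open whether the nitrile itself matters. An amine or a carboxylic acid at that ring carbon would help to test this.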